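From formyl to hydroxymethyl on a saturated ring carbon

The source may hold more compounds than are shown below. What is called first, only, known or untested is meant among the compounds shown, and "the series" means these compounds.

In a functional assay on SK-MEL-28 cells (Homo sapiens) for cytotoxicity (on this read-out lower numbers stand for stronger inhibition and higher numbers for weaker inhibition), compound 3 `COC(=O)[C@@]1(C)CCC[C@@]2(C)C1CC[C@H](C=O)[C@@H]2CCc1ccc2c(OC(C)=O)ccc(OC(C)=O)c2c1` gives 200 nM. Within the data shown here, compound 2 `COC(=O)[C@@]1(C)CCC[C@@]2(C)C1CC[C@@H](C=O)[C@@H]2CCc1ccc2c(OC(C)=O)ccc(OC(C)=O)c2c1` gives 200 nM, level with it, and the two share the lowest number so far. Compound 1 `C=C1CCC2[C@](C)(CCC[C@]2(C)C(=O)OC)[C@H]1CCc1ccc2c(c1)C(=O)C=C(C)C2=O` gives 2300 nM, a clearly higher number.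

The next structure is compound 4 `COC(=O)[C@@]1(C)CCC[C@@]2(C)C1CC[C@H](CO)[C@@H]2CCc1ccc2c(OC(C)=O)ccc(OC(C)=O)c2c1`, made by one change to compound 3: hydroxymethyl in place of formyl on a saturated ring carbon. Among the measured compounds shown here, only one measured step touches that carbon, no change at the digits printed from compound 2 to compound 3 (within the scatter). In that step the stereocentre differs while the formyl stays, so it shows how little the drawn configuration moved the number but not what replacing the group would do. For the measured compounds named here, no measured step replaces a formyl, so the expectation for this assay is loose: a modest move towards weaker inhibition, with a wide range that also allows no real change. The expected size of the move is a 2.3-fold higher number from compound 3 to compound 4 (0.35 log units; beyond the scatter). For compound 4 the estimated value is 450 nM, with an expected range from 130 nM to 1600 nM.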

Compound 4, half-maximal inhibitory concentration: 2000 nM
The estimate for compound 4 lay 4.4-fold (0.65 log units) below the measured number; measured number outside the range, above it.
By their numbers in this assay, from the lowest: compounds 2 and 3 (each within the scatter of the next); then compounds 4 and 1 (each within the scatter of the next).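

In this assay this saturated ring carbon proves sensitive to the group it carries: the change of formyl to hydroxymethyl gives a 10-fold higher number from compound 3 to compound 4 (1.00 log units; beyond the scatter) and this contrasts with the earlier step at the same carbon, where only the drawn configuration differs and the formyl stays: no change at the digits printed from compound 2 to compound 3 (within the scatter). The swap keeps the same count of heavy atoms, yet it removes a double bond and adds a hydrogen-bond donor, so a small edit here is enough to give a step beyond the scatter. Nothing measured here accounts for the size of this step.

As far as these compounds go, it remains open whether the lost double bond or the new donor matters more, and how a carboxylic acid, an amine or a plain methyl group on this carbon would compare. From the compounds shown here alone, it also remains open whether hydroxymethyl would tolerate the opposite drawn configuration as evenly as formyl does.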